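The source may hold more compounds than are shown below. What is called first, only, known or untested is meant among the compounds shown, and "the series" means these compounds.

Measured compounds:
- compound 1, `CCOc1cc(C(=O)Nc2ccc(Cl)c(-c3nc4ccccc4s3)c2)cc(OCC)c1OCC`: in a functional assay on Shh Light II cells for inhibition of Sonic hedgehog protein (Mus musculus), read by reporter gene assay, with a stated time of 48 h, in the presence of a further agent that is not named here (on this read-out lower numbers stand for stronger inhibition and higher numbers for weaker inhibition), compound 1 gives "not active" (no number reported)
- compound 2, `O=C(Nc1ccc(Cl)c(-c2nc3ccccc3[nH]2)c1)c1ccc(Cl)cc1`: in this assay compound 2 gives 224 nM

Compound 1 has no single number on this read-out; for compound 1 the record in this assay is simply "not active" (no number reported), so its place among the numbers cannot be fixed. Within the data shown here, compound 2 does carry a number, 224 nM in this assay, and compound 2 differs from compound 1 in more than one place, so no single step between the two can be set out.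

Compound 3, `CCOc1cc(C(=O)Nc2ccc(Cl)c(C3=NCCN3)c2)cc(OCC)c1OCC`, has not yet been measured. Compared with compound 1 the change is a group of 5 heavy atoms (3 carbon, 2 nitrogen; one five-membered non-aromatic ring with 2 hetero atoms) in place of a group of 9 heavy atoms (7 carbon, 1 nitrogen, 1 sulfur; one five-membered aromatic ring with 2 hetero atoms, one six-membered aromatic ring of carbon only), on an aromatic carbon. Among the measured compounds shown here, no step between two measured compounds follows this change, so the size of the expected step in this assay rests on compound 1 alone, and compound 1 offers no number to step from. A large change in either direction cannot be ruled out, and a result that again gives only a limit is as plausible as a number.

Compound 3 is estimated to give about 5000 nM in this assay, expected to lie between 800 nM and 30000 nM.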

Compound 3, half-maximal inhibitory concentration: "not active" (no number reported)
The entry for compound 3 holds no number, so the estimate cannot be set against anything.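

In this assay, among these compounds, compound 1 gives "not active" (no number reported) and compound 3 gives "not active" (no number reported), so neither has a number and no step between them can be read. From the compounds shown here alone, whether replacing the 1,3-benzothiazol-2-yl group with the five-membered non-aromatic ring changes inhibition at all stays open. No measured evidence shown here bears on this result.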